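This account rests on a few compounds, and the source may have more. Where it says the series, first, only, none or still open, it means among the compounds named here.

Measured so far in an assay for inhibition of Dihydrofolate reductase (Bos taurus), at pH 6.25; a higher number here means a more potent compound, by a factor of ten per unit of this negative logarithm, a lower number a less potent compound:

- compound 1, `CSc1ccccc1N1C(N)=NC(N)=NC1(C)C`: 3.54
- compound 2, `CC1(C)N=C(N)N=C(N)N1c1ccccc1F`: 4.86
- compound 3, `CC1(C)N=C(N)N=C(N)N1c1ccccc1O`: 3.86

Compound 3 stands second highest of the three numbers. Its nearest neighbour is compound 1, with the step of a number 0.32 log units higher from compound 1 to compound 3 (beyond the scatter); its furthest is compound 2, with the step of a number 1.00 log units lower from compound 2 to compound 3 (beyond the scatter). The remaining step, a number 1.32 log units higher from compound 1 to compound 2 (beyond the scatter), marks the widest spread in the set.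

Compound 4, `CC1(C)N=C(N)N=C(N)N1c1ccccc1C(F)(F)F`, differs from compound 3 by trifluoromethyl in place of hydroxy on an aromatic carbon.

Among the measured compounds shown here, two measured steps bear on this. The step of a number 1.00 log units lower from compound 2 to compound 3 (beyond the scatter) shows that removing hydroxy in favour of a fluorine-bearing group gave a modest gain, and the step of a number 0.32 log units higher from compound 1 to compound 3 (beyond the scatter) shows that hydroxy sat only a little above the methylsulfanyl-bearing compound 1. Trifluoromethyl enters with four heavy atoms, three of them fluorine, so the new compound sits somewhere between the pattern set by compound 2 and that set by compound 1. A moderate rise in this assay is therefore expected, though a flat result cannot be ruled out.

For compound 4 the expected value in this assay is 4.4, with a range from 3.6 to 5.2. This estimate corresponds to an expected step of a number 0.54 log units higher from compound 3 to compound 4 (beyond the scatter), expected because compound 2 reached 4.86.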

Compound 4, logarithm of the reciprocal of the active concentration, log(1/C): 3.15
Beside the measured number, compound 4's estimate is 1.25 log units above it; measured number below the stated range.
By their numbers in this assay, from the lowest: compound 4; then compound 1; then compound 3; then compound 2.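

Notes on the group on an aromatic carbon, ortho to a large group: in this assay the result for fluoro does not carry over to the larger fluorine-bearing group, since trifluoromethyl in place of fluoro gives the largest step in the series so far (a number 1.71 log units lower from compound 2 to compound 4 (beyond the scatter)). Trifluoromethyl also falls short of both non-fluorinated groups, hydroxy (a number 0.71 log units lower from compound 3 to compound 4 (beyond the scatter)) and methylsulfanyl (a number 0.39 log units lower from compound 1 to compound 4 (beyond the scatter)), which makes compound 4 the least potent of the four and leaves compound 2 the most potent, so the presence of fluorine alone does not set the level at this position. No measurement in hand bears on the reason for this order.

Open, as far as these compounds go, is where other groups on this carbon would fall in the order, for example chloro, methyl, methoxy or an amine, and whether any of them would come close to fluoro or pass it. Also open, from the compounds shown here alone, is whether the order seen here among fluoro, hydroxy, methylsulfanyl and trifluoromethyl would hold for the same groups elsewhere on the six-membered aromatic ring.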